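Swapping benzyloxycarbonyl for methylsulfonyl on compound 3

This account rests on a few compounds, and the source may have more. Where it says the series, first, only, none or still open, it means among the compounds named here.

Compound 1 (`COc1ccc(/C=C2\CCC=CC2=O)cc1`): 1620 nM
Compound 2 (`COc1cc(/C=C2\CCC=CC2=O)cc(OC)c1OC`): 670 nM
Compound 3 (`COc1cc(/C=C2\CN(C(=O)OCc3ccccc3)C=CC2=O)cc(OC)c1OC`): 24200 nM

All three values come from a functional assay on MDA-MB-231 cells (Homo sapiens) for antiproliferative activity, read by sulforhodamine B assay, with a stated time of 72 h (a lower number here means a stronger inhibitor, a higher number a weaker inhibitor), and are shown above. Compound 3 has the highest number of the three, so it is the weakest inhibitor here, and its gap to both compound 1 and compound 2 lies beyond the usual scatter.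

Compound 4 (`COc1cc(/C=C2\CN(S(C)(=O)=O)C=CC2=O)cc(OC)c1OC`) is still unmeasured. It has methylsulfonyl in place of benzyloxycarbonyl on an amine nitrogen in a ring and otherwise matches compound 3.

Among the measured compounds shown here, no measured pair shows this change on its own, so the expectation is uncertain. Compound 3 at 24200 nM stands well above compound 2 at 670 nM and leaves plenty of room for a lower number. A moderate fall in this assay is therefore expected, an estimated 4.0-fold lower number from compound 3 to compound 4 (0.61 log units; beyond the scatter) (a stronger inhibitor), though no change beyond the scatter remains possible. Compound 4 is estimated at 6000 nM (range 1200 nM to 30000 nM).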

Compound 4, half-maximal inhibitory concentration: 15900 nM
Compound 4: middle estimate off by 2.7-fold (0.42 log units), on the low side; the measured number falls inside the stated range.
By their numbers in this assay, from the lowest: compound 2; then compound 1; then compounds 4 and 3 (each within the scatter of the next).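

Swapping benzyloxycarbonyl for methylsulfonyl on the amine nitrogen in a ring gives a 1.5-fold lower number from compound 3 to compound 4 (0.18 log units; within the scatter) in this assay, so this change cannot be told apart from repeat-measurement noise. Among the compounds shown here, this is the first direct look at a single change at this position: a group with 10 heavy atoms and a six-membered aromatic ring of carbon only gives way to one with 4 heavy atoms and no ring, with no shift beyond the scatter. Nothing measured here explains why the number holds so steady.

Still open, on these data alone, is whether a small acetyl group, or a plain hydrogen on this nitrogen, would stay within the scatter of these two compounds. A longer sulfonyl chain such as butylsulfonyl, or a phenylsulfonyl group, is also untested in the compounds shown.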